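Halogen Swap on the Phenyl Ring: Expecting Cytotoxicity

This account rests on a few compounds, and the source may have more. Where it says the series, first, only, none or still open, it means among the compounds named here.

Measured compounds:
compound 1 `C=CC(=O)Nc1cc(Nc2ncc3ncn(-c4ccccc4)c3n2)c(OC)cc1N(C)CCN(C)C`: 8080 nM
compound 2 `C=CC(=O)Nc1cc(Nc2ncc3ncn(-c4ccc(Cl)cc4)c3n2)c(OC)cc1N(C)CCN(C)C`: 7690 nM

In an ADME assay on HT-29 cells (Homo sapiens) for cytotoxicity, read by MTT assay, with a stated time of 72 h (on this read-out lower numbers stand for stronger inhibition and higher numbers for weaker inhibition), compound 1 gives 8080 nM, the higher of the two numbers shown, although its nearest neighbour, compound 2, gives 7690 nM and the two lie within the scatter of each other. Compound 3 `C=CC(=O)Nc1cc(Nc2ncc3ncn(-c4ccc(I)cc4)c3n2)c(OC)cc1N(C)CCN(C)C` has not yet been measured. It differs from compound 1 by iodo in place of hydrogen on an aromatic carbon. Among the measured compounds shown here, the only measured step that bears on this change is the one from hydrogen to chloro at the same place, a 1.1-fold lower number from compound 1 to compound 2 (0.02 log units; within the scatter), which did not move the number beyond the scatter. For the measured compounds named here, with only that one step as a guide, no shift beyond the scatter is expected: the step of a 1.0-fold lower number from compound 1 to compound 3 (0.00 log units; within the scatter) is estimated to be small. Compound 3 is therefore expected to give about 8000 nM in this assay, with a plausible range from 4000 nM to 16000 nM.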

Compound 3, half-maximal inhibitory concentration: 9520 nM
Compound 3: the middle estimate sits 1.2-fold (0.08 log units) below what was measured, and the stated range covers the measured number.
By their numbers in this assay, from the lowest: compounds 2, 1 and 3 (each within the scatter of the next).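

With iodo at this place, this assay shows a 1.2-fold higher number from compound 1 to compound 3 (0.07 log units; within the scatter), and exchanging one halogen for the other shows a 1.2-fold higher number from compound 2 to compound 3 (0.09 log units; within the scatter). The chloro step alone covered a single halogen; now hydrogen, chloro and iodo on this aromatic carbon, para to a large group, all give numbers that cannot be told apart on this read-out, so a second and much larger halogen atom has also left the cytotoxicity reading in the same range. Nothing shown here offers an explanation for this flat result. Still open, from the compounds shown here alone, is whether a group of a different kind at this place, such as an amine, a carboxylic acid or a longer chain, would move the number beyond the scatter. Also open, going by these compounds, is whether the halogens would behave alike on another carbon of the same ring.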